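Nitrophenyl Sulfonamide Among Chemokine Receptor Ligands

This account rests on a few compounds, and the source may have more. Where it says the series, first, only, none or still open, it means among the compounds named here.

Measured compounds:
compound 1 `Cc1ccccc1C(=O)NCc1ccc(CNS(=O)(=O)c2ccc(F)cc2)cc1` 10 nM
compound 2 `COc1ccccc1C(=O)NCc1ccc(CNS(=O)(=O)c2ccc([N+](=O)[O-])cc2)cc1` 100 nM
compound 3 `Cc1ccccc1C(=O)NCc1ccc(CNS(=O)(=O)c2cccc(Cl)c2)cc1` 100 nM

These three share one core and differ in the aryl group on the sulfonyl sulfur and in the substituent on the benzamide ring. In an assay on MDA-MB-231 cells for displacement of a labelled ligand from C-X-C chemokine receptor type 4 (Homo sapiens), read by fluorescence and microscopy, with stated times of 10 min and 30 min (a higher number here means that more compound is needed for the effect, a lower number that less compound is needed), compound 3 gives 100 nM, level with compound 2 at the digits shown, and the two together carry the highest numbers of the set; compound 1 sits a full step lower, as a 10-fold higher number from compound 1 to compound 3 (1.00 log units; beyond the scatter) records.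

Compound 4 `Cc1ccccc1C(=O)NCc1ccc(CNS(=O)(=O)c2ccc([N+](=O)[O-])cc2)cc1` is not yet measured. It differs from compound 3 in one place: 4-nitrophenyl in place of 3-chlorophenyl on a sulfonyl sulfur. For the measured compounds named here, the one step that bears on this position, a 10-fold higher number from compound 1 to compound 3 (1.00 log units; beyond the scatter), shows that swapping the aryl group on the sulfonyl sulfur can move the number by a sizeable amount. Compound 2 already carries the 4-nitrophenyl group, though with a different benzamide substituent, and gives 100 nM. Going by the values given here, no step links compound 2 to compound 4, so its value serves only as a pointer. On that basis compound 4 is expected to stay near compound 3, with no change at the digits printed from compound 3 to compound 4 (within the scatter) lying within the scatter. The estimate for compound 4 is 100 nM, ranging from 30 nM to 300 nM.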

Compound 4, effective concentration (reported as EC, without a stated level of effect): 100 nM
The estimate for compound 4 equals the measured number at the digits printed; low and high end bracket the measured number.
By their numbers in this assay, from the lowest: compound 1; then compounds 2, 3 and 4 (each within the scatter of the next).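

In this assay the step of no change at the digits printed from compound 3 to compound 4 (within the scatter) shows that this position on the sulfonyl sulfur tolerates the exchange of 3-chlorophenyl for 4-nitrophenyl without any readable shift, even though the entering group is larger and carries hydrogen-bond acceptors that the leaving group lacks. For the compounds shown here, the step of no change at the digits printed from compound 2 to compound 4 (within the scatter) gives the first direct reading of methyl in place of methoxy on an aromatic carbon, and with the 4-nitrophenyl group held constant this exchange also leaves the number unmoved. Nitro in place of fluoro on an aromatic carbon gives a 10-fold higher number from compound 1 to compound 4 (1.00 log units; beyond the scatter) and so, among these four compounds, only compound 1 with its 4-fluorophenyl group stands apart from the others.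

No measurement offered here explains why compound 1 differs from the rest. On these data alone, it also remains open whether a 4-fluorophenyl group would keep its lower number alongside methoxy in place of methyl, and whether an aryl group on the sulfonyl sulfur bearing an amine or a carboxylic acid would fall with compound 1 or with compound 4.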